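From a selenium-bearing chain to 2-aminoethoxy

This account rests on a few compounds, and the source may have more. Where it says the series, first, only, none or still open, it means among the compounds named here.

In a functional assay on HCT-116 cells (Homo sapiens) for inhibition, read by MTT assay, with a stated time of 48 h (on this read-out higher numbers stand for weaker inhibition and lower numbers for stronger inhibition), compound 1 (`COc1ccc(N(C)c2nc(C)nc3ccccc23)cc1C(=O)NCC[Se]C#N`) gives 313 nM as the higher of two numbers. In the same read-out compound 2 (`C[Se]c1ccc(N(C)c2nc(C)nc3ccccc23)cc1Cl`) gives 5 nM. The gap between these two numbers lies beyond the scatter. Compound 3 (`COc1ccc(N(C)c2nc(C)nc3ccccc23)cc1OCCN`) brings in 2-aminoethoxy on an aromatic carbon, ortho to a methoxy group and meta to a large group (a group of 4 heavy atoms (2 carbon, 1 nitrogen, 1 oxygen; no ring) in place of a group of 8 heavy atoms (4 carbon, 2 nitrogen, 1 oxygen, 1 selenium; no ring), on an aromatic carbon). Going by the values given here, no measured pair isolates this change. Among the compounds with values here, compound 2 at 5 nM shows only that much lower numbers occur. On that thin ground a moderate step towards stronger inhibition is expected in this assay (a 3.1-fold lower number from compound 1 to compound 3 (0.50 log units; beyond the scatter)). Compound 3 is estimated at 100 nM within a range from 15 nM to 600 nM for this expectation.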

Compound 3, half-maximal inhibitory concentration: 198 nM
For compound 3 the middle estimate is 2.0-fold (0.30 log units) below the measured one, within the range that was stated.
By their numbers in this assay, from the lowest: compound 2; then compounds 3 and 1 (each within the scatter of the next).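

In this assay, 2-aminoethoxy in place of the selenium-bearing group of 8 heavy atoms, on an aromatic carbon ortho to a methoxy group and meta to a large group, gives a step that stays within the scatter (a 1.6-fold lower number from compound 1 to compound 3 (0.20 log units; within the scatter)). Going by these compounds alone, this is the first direct comparison at this position, and it shows that the two groups cannot be told apart in this read-out, even though selenium is absent from the entering group. No evidence on hand bears on this result. On these data alone, it remains open how a longer chain ending in an amine, or a carboxylic acid, would read at this position.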